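The source may report more compounds than this note shows. Statements on the series, on what has been measured and on what is new or still open speak of the compounds shown alone.

Measured so far in an assay on cells for activation of Guanylate cyclase soluble subunit alpha-1 (Rattus norvegicus), read by cGMP accumulation and immunoassay, with a stated time of 10 min; on this read-out lower numbers stand for an effect already at smaller amounts and higher numbers for an effect only at larger amounts of compound:

compound 1 `COC(=O)N(CCO)c1c(N)nc(-c2nn(Cc3ccccc3F)c3ncccc23)nc1N`: 0.3 uM
compound 2 `CC(C)OC(=O)Nc1c(N)nc(-c2nn(Cc3ccccc3F)c3ncccc23)nc1N`: 0.8 uM

Within the data shown here, compound 1 holds the lower of the two numbers in this assay; the only measured step from it is a 2.7-fold higher number from compound 1 to compound 2 (0.43 log units; beyond the scatter), which is modest but lies beyond the scatter.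

Compound 3 `Nc1nc(-c2nn(Cc3ccccc3F)c3ncccc23)nc(N)c1NC(=O)OCC(F)(F)F` is not yet measured in this assay. It differs from compound 1 as follows: ((2,2,2-trifluoroethoxy)carbonyl)amino in place of (2-hydroxyethyl)(methoxycarbonyl)amino on an aromatic carbon. Among the measured compounds shown here, the change to compound 2 also removed the (2-hydroxyethyl)(methoxycarbonyl)amino group in favour of a carbamate bearing a single hydrogen on nitrogen, so the step of a 2.7-fold higher number from compound 1 to compound 2 (0.43 log units; beyond the scatter) is the one measured step that bears on it. A step of similar size and direction is therefore expected, with the unmeasured ester alkyl leaving room on both sides.

Compound 3 is expected to give 0.7 uM in this assay, within 0.3 uM to 1.8 uM. The expected step is a 2.3-fold higher number from compound 1 to compound 3 (0.37 log units; beyond the scatter).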

Compound 3, minimum effective concentration: 0.2 uM
Beside the measured number, compound 3's estimate is 3.5-fold (0.54 log units) above it; measured number outside the range, below it.
By their numbers in this assay, from the lowest: compounds 3 and 1 (each within the scatter of the next); then compound 2.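

In this assay, the ester alkyl on this carbamate affects the read-out: a 4.0-fold lower number from compound 2 to compound 3 (0.60 log units; beyond the scatter) comes with 2,2,2-trifluoroethyl in place of isopropyl, a modest change beyond the scatter. With a 1.5-fold lower number from compound 1 to compound 3 (0.18 log units; within the scatter), ((2,2,2-trifluoroethoxy)carbonyl)amino and (2-hydroxyethyl)(methoxycarbonyl)amino cannot be told apart here, so a carbamate with a hydrogen on nitrogen and no 2-hydroxyethyl group does not by itself carry the higher number of compound 2. The data at hand give no explanation for the difference between these two ester alkyl groups.

Still open, going by these compounds, is whether an unfluorinated ethyl ester would track with compound 3 or with compound 2, which would separate the fluorine atoms from the size of the ester alkyl. Also open, on these data alone, is how a urea or an amide in place of the carbamate would read at this position.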